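A few compounds are considered here, and "the series" means these few. Any claim that something is new, unique, unknown or untested is made for them only; others in the source may bear on it.

Three compounds have been measured in an ADME assay on Vero cells (Chlorocebus sabaeus) for inhibition, read by sulforhodamine B assay, with a stated time of 48 h; a lower number here means a stronger inhibitor of growth, a higher number a weaker inhibitor of growth:

Compound 2 `COc1ccc(/C=N/NC(=S)NC(C)(C)[C@H]2CC=C(C)CC2)cc1` gives 12200 nM in this assay.
Compound 1 `CC1=CC[C@H](C(C)(C)N=C=S)CC1` gives > 100000 nM in this assay, which is a limit of the assay and not a number.
Compound 3 `CC1=CC[C@H](C(C)(C)NC(=S)N/N=C/c2cccc([N+](=O)[O-])c2)CC1` gives > 100000 nM in this assay, also a limit and not a number.

Among the compounds with values here, compound 2 therefore stands as the only compound with a number in this assay; the two other values shown are limits, as recorded in the limit of > 100000 nM in this assay, at which 2 of the 3 values shown sit. Compound 1 sits at that limit. Compound 3 sits at that limit too.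

Compound 4 `CC1=CC[C@H](C(C)(C)NC(=S)N/N=C/c2ccco2)CC1` differs from compound 2 in one place: furan-2-yl in place of 4-methoxyphenyl on a carbon with a double bond to nitrogen. Within the data shown here, no step between two measured compounds describes such a change, so there is nothing to borrow. The expectation for this assay is a small step toward a weaker inhibitor of growth, or none beyond the scatter. The step from compound 2 to compound 4 is estimated at a 1.6-fold higher number from compound 2 to compound 4 (0.21 log units; within the scatter) in this assay. Compound 4 is thus expected to give about 20000 nM in this assay, within a range from 6000 nM to 70000 nM.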

Compound 4, concentration for 50% growth inhibition: 5100 nM
Estimate against measurement, compound 4: 3.9-fold (0.59 log units) above; the whole stated range lies above it.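

Putting furan-2-yl in place of 4-methoxyphenyl on a carbon with a double bond to nitrogen gives a 2.4-fold lower number from compound 2 to compound 4 (0.38 log units; beyond the scatter) in this assay. Within the data shown here, this is the only step that can be read at this place, and it shows that a five-membered aromatic ring with 1 hetero atom, with fewer heavy atoms than the group it replaces, does not cost inhibition of growth here but brings a modest strengthening. Numbers at this place remain scarce, with the other compounds shown sitting at a limit of the assay and not at a number: the limit of > 100000 nM in this assay, at which 2 of the 4 values shown sit.

One step cannot tell whether the change follows from the ring size, the ring oxygen or the loss of the methoxy group. From the compounds shown here alone, how an unsubstituted phenyl or a thiophen-2-yl would behave at this place remains open.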